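A few compounds are considered here, and "the series" means these few. Any claim that something is new, unique, unknown or untested is made for them only; others in the source may bear on it.

Measured so far in a physicochemical assay for solubility; a lower number here means a less soluble compound, a higher number a more soluble compound:

Compound 1, `O=C(O)c1ccc(C(=O)/C(=C\c2ccc(F)c([N+](=O)[O-])c2)S(=O)(=O)Cc2ccc(Br)cc2)cc1`, gives < 1000 ug/mL in this assay; that is a limit of the assay, not a number.
Compound 2, `O=C(O)c1ccc(C(=O)/C(=C\c2ccc(Cl)c([N+](=O)[O-])c2)SCc2ccc(Cl)cc2)cc1`, gives < 1000 ug/mL in this assay; that, too, is a limit.
Compound 3, `O=C(O)c1ccc(C(=O)/C(=C\c2ccc([N+](=O)[O-])c(F)c2)SCc2ccc(Br)cc2)cc1`, gives < 1000 ug/mL in this assay; again a limit rather than a number.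

For the measured compounds named here, compound 3 therefore stands nowhere in particular among the three: every value reported so far is the limit of < 1000 ug/mL in this assay, at which 3 of the 3 values shown sit, so no order can be drawn between compound 1, compound 2 and compound 3, and no measured step between any pair of them is available.

The next compound, compound 4, is `O=C(O)c1ccc(C(=O)/C(=C\c2ccc(O)c(Br)c2)SCc2ccc(Br)cc2)cc1`. It differs from compound 3 in one place: 3-bromo-4-hydroxyphenyl in place of 3-fluoro-4-nitrophenyl on a double-bonded chain carbon bound to a double-bonded chain carbon. Going by the values given here, since no step between measured compounds has been characterised, the size of the change in this assay cannot be drawn from any comparison already made.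

Taking only the fact that compound 3 sits at the limit, the step is expected to be a step that the limit leaves unreadable from compound 3 to compound 4, that is, no reliable move in either direction beyond the scatter. Compound 4 is accordingly estimated at 200 ug/mL in this assay, with a range from 30 ug/mL to 1000 ug/mL.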

Compound 4, solubility: < 1000 ug/mL
Compound 4 ended at the assay's limit; the forecaster's own chance of this, stated with the estimate: 60%; the middle value is on the limit's open side.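

No step can be read from compound 3 to compound 4, because both values are limits rather than numbers: the limit of < 1000 ug/mL in this assay, at which 4 of the 4 values shown sit.

The compounds shown leave open where compound 1, compound 2, compound 3 and compound 4 actually lie in this assay, and whether 3-bromo-4-hydroxyphenyl in place of 3-fluoro-4-nitrophenyl changes the read-out at all.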